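A few compounds are considered here, and "the series" means these few. Any claim that something is new, unique, unknown or untested is made for them only; others in the source may bear on it.

In a functional assay on HeLa cells (Homo sapiens) for cytotoxicity, read by sulforhodamine B assay (on this read-out lower numbers stand for stronger inhibition and higher numbers for weaker inhibition), compound 1 `CC(C)C(NS(=O)(=O)c1ccc(Br)cc1)C1=CC(=O)c2c(O)ccc(O)c2C1=O` gives 7650 nM and compound 2 `CC(=O)c1ccc(S(=O)(=O)NC(C2=CC(=O)c3c(O)ccc(O)c3C2=O)C(C)C)cc1` gives 3820 nM, so the two values lie within the scatter of each other. Compound 3 `CC(NS(=O)(=O)c1ccc(Br)cc1)C1=CC(=O)c2c(O)ccc(O)c2C1=O` keeps the core of compound 1 and has methyl in place of isopropyl on a saturated chain carbon bound to a double-bonded ring carbon and a sulfonamide nitrogen. Among the compounds with values here, the only measured step, a 2.0-fold lower number from compound 1 to compound 2 (0.30 log units; within the scatter), swaps bromo for acetyl on an aromatic carbon, so it does not test this chain carbon and stayed within the scatter. With no measured guide to direction, the expected change is no larger than the scatter, and the estimated step is a 1.3-fold lower number from compound 1 to compound 3 (0.11 log units; within the scatter). Compound 3 is expected near 6000 nM, with an estimated range of 2000 nM to 18000 nM.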

Compound 3, half-maximal inhibitory concentration: 5210 nM
Compound 3: the middle estimate sits 1.2-fold (0.06 log units) above what was measured, and the stated range covers the measured number.
By their numbers in this assay, from the lowest: compounds 2, 3 and 1 (each within the scatter of the next).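

Placing methyl in place of isopropyl on this saturated chain carbon gives a 1.5-fold lower number from compound 1 to compound 3 (0.17 log units; within the scatter) in this assay and is the first change tested at this position. The isopropyl group is therefore not required for a value in this range, and a single carbon there serves as well within the scatter. Nothing available explains this result.

From the compounds shown here alone, whether a longer chain, a phenyl ring or an amine on this carbon would move the number beyond the scatter remains open. Also open, going by these compounds, is whether acetyl in place of bromo would behave the same way with methyl on this carbon.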